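This account rests on a few compounds, and the source may have more. Where it says the series, first, only, none or still open, it means among the compounds named here.

Values in a functional assay on A2780 cells (Homo sapiens) for antiproliferative activity, read by MTT assay, with a stated time of 48 h; on this read-out lower numbers stand for stronger inhibition and higher numbers for weaker inhibition:
compound 1 `COc1ccc(C(=O)c2ccc3c(c2)C=CC(C)(C)O3)c(NC(=O)CO)c1` gives 130 nM
compound 2 `COc1ccc(C(=O)c2ccc3c(c2)C=CC(C)(C)O3)c(NC(=O)CN)c1` gives 590 nM
compound 3 `C=C(c1ccc(OC)cc1NC(=O)CO)c1ccc(OC)c2c1C=CC(C)(C)O2` gives 280 nM

Compound 1 and compound 2 share a core and differ only by amino in place of hydroxy on a saturated chain carbon bound to a carbonyl carbon. That step read a 4.5-fold higher number from compound 1 to compound 2 (0.66 log units; beyond the scatter). Compound 3 stands on a different core; how the two cores differ is not broken down here. Its number lies between the other two, higher than compound 1 and lower than compound 2, both gaps beyond the scatter.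

Compound 4 `C=C(c1ccc(OC)cc1NC(=O)CN)c1ccc(OC)c2c1C=CC(C)(C)O2` has not yet been measured. It differs from compound 3 by amino in place of hydroxy on a saturated chain carbon bound to a carbonyl carbon, at the same place as the change from compound 1 to compound 2, so it is the same change carried onto the core of compound 3. Among the compounds with values here, only one earlier instance of this change exists, and it sits on another core, so the expectation rests on a single point.

Within the data shown here, the step from compound 3 to compound 4 in this assay is expected to be a 3.9-fold higher number from compound 3 to compound 4 (0.59 log units; beyond the scatter), because the one earlier instance of the change gave a 4.5-fold higher number from compound 1 to compound 2 (0.66 log units; beyond the scatter). Compound 4 is therefore estimated at 1100 nM, expected to fall between 500 nM and 2500 nM.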

Compound 4, half-maximal inhibitory concentration: 400 nM
Beside the measured number, compound 4's estimate is 2.8-fold (0.44 log units) above it; measured number outside the range, below it.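

In this assay, amino in place of hydroxy on a saturated chain carbon bound to a carbonyl carbon gives a 1.4-fold higher number from compound 3 to compound 4 (0.15 log units; within the scatter), so on the core of compound 3 this change produces no step beyond the scatter. These two instances show that the size of the step cannot be taken as fixed from one core to the other, but they do not show what in the cores sets the size of the step, how the change would read on a third core, or which property of either group is involved. The size of the step did not carry over, and the two instances differ: the same change on two cores in this assay, a 4.5-fold higher number (0.66 log units; beyond the scatter) from compound 1 to compound 2 and a 1.4-fold higher number (0.15 log units; within the scatter) from compound 3 to compound 4, 3.2-fold (0.50 log units) apart, beyond the scatter of two such steps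

The compounds shown leave open whether other groups at this place, such as a dimethylamino group, a carboxylic acid or a longer chain such as aminoethyl, would also read differently on the two cores. Also open is which part of the difference between the two cores accounts for the gap between the two steps.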